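Swapping the aryl group on a nucleoside-like cytotoxicity series

The source may hold more compounds than are shown below. What is called first, only, known or untested is meant among the compounds shown, and "the series" means these compounds.

Four compounds share the same core and differ only in the aromatic group hung from a saturated chain carbon bound to a nitrogen on an aromatic ring. For the measured compounds named here, compound 1, `COc1ccccc1CNc1ncnc2c1ncn2[C@@H]1O[C@H](CO)[C@@H](O)[C@H]1O`, is the one with a number: in an ADME assay on NIH3T3 cells (Mus musculus) for cytotoxicity, with a stated time of 72 h (on this read-out lower numbers stand for stronger inhibition and higher numbers for weaker inhibition), compound 1 gives 140000 nM, a weak effect on the cells. Compound 2, `OC[C@H]1O[C@@H](n2cnc3c(NCc4ccc(Cl)cc4Cl)ncnc32)[C@H](O)[C@@H]1O`, has no result in this assay: for compound 2 the entry reads "not determined" (no result reported). Compound 3, `OC[C@H]1O[C@@H](n2cnc3c(NCc4c(F)ccc(F)c4F)ncnc32)[C@H](O)[C@@H]1O`, likewise stands without a single number in this assay, its entry for compound 3 being "not determined" (no result reported), so nothing can be said of how it compares with compound 1. The new member is compound 4, `OC[C@H]1O[C@@H](n2cnc3c(NCc4ccc(F)c(Cl)c4)ncnc32)[C@H](O)[C@@H]1O`. The change from compound 3 to compound 4 is 3-chloro-4-fluorophenyl in place of 2,3,6-trifluorophenyl on a saturated chain carbon bound to a nitrogen on an aromatic ring. Going by the values given here, no measured pair in this set differs in one place, so there is no step to lean on. Since compound 1 with its own aromatic group gives 140000 nM, compound 4 is expected to sit in the same weak region, with any difference from such a value expected to fall within the usual scatter rather than in a clear direction. For compound 4 the estimated value in this assay is 120000 nM, with a range from 40000 nM to 300000 nM.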

Compound 4, half-maximal inhibitory concentration: > 166000 nM
Compound 4 ended at the assay's limit (the forecaster's own chance of this, stated with the estimate: 40%); middle value at least 1.3-fold (0.14 log units) from the limit.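

In this assay the result for compound 4 is a limit of the assay and not a number: the limit of > 166000 nM in this assay, at which 1 of the 4 values shown sits. Putting 3-chloro-4-fluorophenyl in place of 2-methoxyphenyl on a saturated chain carbon bound to a nitrogen on an aromatic ring gives an at least 1.1-fold higher number from compound 1 to compound 4 (0.07 log units; that floor lies within the scatter), so the readable part of this change is no clear shift in either direction. For the compounds shown here, what the earlier compounds could not show is that a second aromatic group at this position, now one carrying chlorine and fluorine instead of a methoxy group, also stays in the weak region of this cell read-out, which for these two compounds points to no strong effect on the cells from either group.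

Going by these compounds, compound 2 and compound 3 have no result, so any step that touches them cannot be read, and how far compound 4 really lies past its limit stays unknown. The compounds shown also leave open what an amine or a carboxylic acid in place of the aromatic group, or a longer chain in place of the saturated chain carbon, would do in this assay.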